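The source may hold more compounds than are shown below. What is called first, only, known or untested is meant among the compounds shown, and "the series" means these compounds.

Working notes on the series. In an assay on cells for inhibition of interleukin-5 receptor subunit alpha (Mus musculus), read by WST assay, with a stated time of 48 h, tested at 30 uM, in the presence of a further agent that is not named here (on this read-out lower numbers stand for less inhibition and higher numbers for more inhibition at the one concentration tested (going by the name of the read-out)), compound 1 `OCCCCCNCc1nc2c(OCC3CCCCC3)cccc2[nH]1` gives 23.7% and stands lowest of the two numbers in hand. Compound 2 `CCCC(CO)NCc1nc2c(OCC3CCCCC3)cccc2[nH]1` gives 73.3% in this assay, a step of a number 49.6 percentage points higher from compound 1 to compound 2 (beyond the scatter). Compound 3 `COc1ccc(NCc2nc3c(OCC4CCCCC4)cccc3[nH]2)cc1` differs from compound 1 by 4-methoxyphenyl in place of 5-hydroxypentyl on an amine nitrogen. Within the data shown here, the one measured step concerns the same amine nitrogen and was large, but it kept a hydroxyl on a chain, whereas here an aromatic ring without a hydrogen-bond donor enters, so its bearing is partial. A moderate rise is expected, by about a number 21.3 percentage points higher from compound 1 to compound 3 (beyond the scatter). For compound 3 the estimate is 45%, within 12% to 78%.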

Compound 3, a percentage reported as inhibition, at one concentration (the size of the read-out at that concentration, not a potency): 20.3%
The estimate for compound 3 lay 24.7 percentage points above the measured number, within the range that was stated.
By their numbers in this assay, from the lowest: compounds 3 and 1 (each within the scatter of the next); then compound 2.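

At the amine nitrogen, 4-methoxyphenyl in place of 5-hydroxypentyl gives a number 3.4 percentage points lower from compound 1 to compound 3 (within the scatter) in this assay, so these two groups cannot be told apart on this read-out, even though one carries an aromatic ring and the other a hydroxyl chain. In place of 1-(hydroxymethyl)butyl, the same group gives a number 53 percentage points lower from compound 2 to compound 3 (beyond the scatter), which leaves compound 2 alone clearly apart from the other two. Nothing at hand bears on the cause of these numbers. Still open, from the compounds shown here alone, is whether the high number of compound 2 depends on the hydroxyl or on the branched chain. A 1-methylbutyl group on this nitrogen would separate the two, and a benzyl group would extend the aromatic comparison.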